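The source may report more compounds than this note shows. Statements on the series, on what has been measured and on what is new or still open speak of the compounds shown alone.

Compound 1, `COc1cccc(Cn2cc(C(=O)Nc3ccc(C)c(S(=O)(=O)N4CCOCC4)c3)c(C(C)C)n2)c1`, gives in an assay on HEK-293T cells for inhibition of Bile acid receptor (Homo sapiens), read by a beta-lactamase reporter, with a stated time of 16 h (on this read-out higher numbers stand for weaker inhibition and lower numbers for stronger inhibition), 3110 nM.
Compound 2, `COc1cccc(Cn2cc(C(=O)Nc3ccc(C)c(S(=O)(=O)N4CCOCC4)c3)c(-c3cccc(OC)c3)n2)c1`, gives in this assay 1240 nM.

Of the compounds shown here, two have been measured, and they share one core that carries a 3-methoxybenzyl group and an amide-linked aryl sulfonamide. Compound 2 stands lowest of the two numbers: the change from isopropyl to 3-methoxyphenyl on the aromatic carbon brought a 2.5-fold lower number from compound 1 to compound 2 (0.40 log units; beyond the scatter), a modest move that lies beyond the scatter.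

Compound 3, `COCCc1nn(Cc2cccc(OC)c2)cc1C(=O)Nc1ccc(C)c(S(=O)(=O)N2CCOCC2)c1`, is the next compound, not yet measured. It differs from compound 2 in one place: 2-methoxyethyl in place of 3-methoxyphenyl on an aromatic carbon. Going by the values given here, the single measured step bears on this change in a loose way only. It showed that putting a six-membered aromatic ring at this carbon in place of a small branched chain lowered the number by a 2.5-fold lower number from compound 1 to compound 2 (0.40 log units; beyond the scatter). Compound 3 again carries a group without a ring at this carbon, so the expectation is that the number moves back up toward that of compound 1. Compound 3 is therefore expected to show a rise of about a 2.3-fold higher number from compound 2 to compound 3 (0.35 log units; beyond the scatter) in this assay. The estimate for compound 3 is 2800 nM, with a range from 1200 nM to 6500 nM.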

Compound 3, half-maximal inhibitory concentration: 11100 nM
Compound 3: middle estimate off by 4.0-fold (0.60 log units), on the low side, and the stated range ends below it.
By their numbers in this assay, from the lowest: compound 2; then compound 1; then compound 3.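

On this aromatic carbon, losing the ring does not simply return the number to that of compound 1: in this assay, 2-methoxyethyl gives a 9.0-fold higher number from compound 2 to compound 3 (0.95 log units; beyond the scatter) and also sits beyond isopropyl, with a 3.6-fold higher number from compound 1 to compound 3 (0.55 log units; beyond the scatter). Two groups without a ring therefore give different numbers, so the absence of a ring does not alone set the result, and the order at this carbon runs from 3-methoxyphenyl through isopropyl to 2-methoxyethyl, with each printed step beyond the usual scatter. 3-Methoxyphenyl and 2-methoxyethyl have the same counts of hydrogen-bond donors and acceptors and no net charge, so these counts do not separate them, and no supporting measurement explains the differences.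

The three groups leave open whether the six-membered aromatic ring or its methoxy group accounts for the lowest number, a question that a plain phenyl group could help answer. They also leave open whether the oxygen in 2-methoxyethyl matters, which a plain butyl chain or an amine-bearing chain at this carbon could test.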